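The source may report more compounds than this note shows. Statements on the series, on what has been measured and on what is new or still open speak of the compounds shown alone.

Of the compounds shown here, three built on one shared core have been measured in a functional assay on MCF7 cells (Homo sapiens) for cytotoxicity, read by MTT assay, with a stated time of 72 h; a lower number here means a stronger inhibitor, a higher number a weaker inhibitor. Compound 1 `CCN(CC)CCCOc1c(OCc2ccccc2)cc(O)c2c(=O)cc(-c3ccccc3)oc12` gives 3210 nM. Compound 2 `CCN(CC)CCCCOc1c(OCc2ccccc2)cc(O)c2c(=O)cc(-c3ccccc3)oc12` gives 1920 nM, and compound 3 `CN1CCN(CCCCOc2c(OCc3ccccc3)cc(O)c3c(=O)cc(-c4ccccc4)oc23)CC1` gives 2930 nM. On these numbers compound 3 stands second highest of the three, nearest to compound 1 and furthest from compound 2, yet every gap among them is within the scatter: a 1.7-fold lower number from compound 1 to compound 2 (0.22 log units; within the scatter), a 1.1-fold lower number from compound 1 to compound 3 (0.04 log units; within the scatter) and a 1.5-fold higher number from compound 2 to compound 3 (0.18 log units; within the scatter). All three measured steps alter the amine end of the chain; none touches the benzyl group on the other side of the core.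

Compound 4 `Cc1ccc(COc2cc(O)c3c(=O)cc(-c4ccccc4)oc3c2OCCCCN2CCN(C)CC2)cc1` differs from compound 3 only at that benzyl group: methyl in place of hydrogen on an aromatic carbon. Going by the values given here, no measured step speaks to this position, so the only guide is that the three measured compounds sit within a narrow band of each other. The expected step is therefore small, with no direction beyond the scatter: a 1.0-fold lower number from compound 3 to compound 4 (0.00 log units; within the scatter). Compound 4 is estimated at 2900 nM, within a range from 1200 nM to 7000 nM.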

Compound 4, half-maximal inhibitory concentration: 2220 nM
Estimate against measurement, compound 4: 1.3-fold (0.12 log units) above; low and high end bracket the measured number.
By their numbers in this assay, from the lowest: compounds 2, 4, 3 and 1 (each within the scatter of the next).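

Changing benzyl to 4-methylbenzyl is the first step shown on this side of the shared core, and in this assay it gives a 1.3-fold lower number from compound 3 to compound 4 (0.12 log units; within the scatter). A single methyl on this aromatic carbon, para to a large group, therefore leaves the cytotoxicity reading indistinguishable from that of the unsubstituted benzyl group, just as the changes at the amine end did. Nothing available here bears on how this result arises.

The compounds shown leave open whether a different group at this position, such as a chlorine atom, a methoxy group or a carboxylic acid, would move the number beyond the scatter. They also leave open whether the same methyl would behave alike on a compound with a diethylamino group at the end of the chain.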